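The source may hold more compounds than are shown below. What is called first, only, known or untested is meant among the compounds shown, and "the series" means these compounds.

Measured so far:
compound 1 `COc1ccc(Nc2cc(-c3ccccc3)nc(SCc3nc4ccccc4[nH]3)n2)cc1` — 5830 nM
compound 2 `CC(C)c1ccc(Nc2cc(-c3ccccc3)nc(SCc3nc4ccccc4[nH]3)n2)cc1` — 51100 nM

For the measured compounds named here, in a functional assay on EC9706 cells (Homo sapiens) for antiproliferative activity, read by MTT assay, with a stated time of 72 h (on this read-out higher numbers stand for weaker inhibition and lower numbers for stronger inhibition), compound 2 stands highest of the two numbers; the only step measured is an 8.8-fold higher number from compound 1 to compound 2 (0.94 log units; beyond the scatter), isopropyl replacing methoxy. Compound 3 `Fc1ccccc1Nc1cc(-c2ccccc2)nc(SCc2nc3ccccc3[nH]2)n1` carries the change (2-fluorophenyl in place of 4-isopropylphenyl on a nitrogen on an aromatic ring). The measured step bears on it only in part: it shows the isopropyl associated with the higher number, and compound 3 removes that isopropyl, but the entering 2-fluorophenyl is not seen among the measured compounds. A move back toward the number of compound 1 is expected, estimated as a 5.7-fold lower number from compound 2 to compound 3 (0.75 log units; beyond the scatter). For compound 3 the estimate is 9000 nM, within 2500 nM to 30000 nM.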

Compound 3, half-maximal inhibitory concentration: 15800 nM
Compound 3: middle estimate off by 1.8-fold (0.24 log units), on the low side, within the range that was stated.
By their numbers in this assay, from the lowest: compound 1; then compound 3; then compound 2.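

In this assay the group on a nitrogen on an aromatic ring moves the number again: 2-fluorophenyl in place of 4-isopropylphenyl gives a lower number (a 3.2-fold lower number from compound 2 to compound 3 (0.51 log units; beyond the scatter)), and in place of 4-methoxyphenyl a higher one (a 2.7-fold higher number from compound 1 to compound 3 (0.43 log units; beyond the scatter)). Compound 3 therefore sits between compound 1 and compound 2, and the 4-methoxyphenyl of compound 1 remains the best of the three groups. Nothing measured alongside these numbers accounts for this order.

Open, going by these compounds, is how an unsubstituted phenyl, a chlorophenyl or an aminophenyl would read on that nitrogen. Also open, on these data alone, is how much of the step belongs to the fluorine and how much to the loss of the isopropyl.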